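Aryl ether swap: trichlorophenyl to bromophenyl

The compounds below may be only part of what the source reports. "The series", "measured", "known", "first", "only" and "open" are said of these compounds alone.

Compound 1 `NC1=NC2(CCOCC2)N(OCCCOc2ccc(Cl)cc2)C(N)=N1`: 360 nM
Compound 2 `NC1=NC2(CCOCC2)N(OCCCOc2cc(Cl)c(Cl)cc2Cl)C(N)=N1`: 680 nM

For the measured compounds named here, of the only two numbers in a functional assay on A549 cells (Homo sapiens) for antiproliferative activity, read by MTT assay, with a stated time of 72 h (a higher number here means a weaker inhibitor, a lower number a stronger inhibitor), that of compound 2, 680 nM, lies within the scatter of the other. Compound 3 `NC1=NC2(CCOCC2)N(OCCCOc2ccccc2Br)C(N)=N1` places 2-bromophenyl in place of 2,4,5-trichlorophenyl on an oxygen on a saturated carbon. Going by the values given here, one measured step bears on this change, a swap at the same place: a 1.9-fold higher number from compound 1 to compound 2 (0.28 log units; within the scatter). On that single step, no shift beyond the scatter is expected in this assay, in either direction. The expected step is a 1.4-fold lower number from compound 2 to compound 3 (0.13 log units; within the scatter). For compound 3 the estimated value is 500 nM, with an expected range of 170 nM to 1400 nM.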

Compound 3, half-maximal inhibitory concentration: 160 nM
For compound 3 the middle estimate is 3.1-fold (0.49 log units) above the measured one; measured number outside the range, below it.
By their numbers in this assay, from the lowest: compound 3; then compounds 1 and 2 (each within the scatter of the next).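

In this assay this position now gives separations beyond the scatter, with 2-bromophenyl in place of 2,4,5-trichlorophenyl (a 4.3-fold lower number from compound 2 to compound 3 (0.63 log units; beyond the scatter)) and in place of 4-chlorophenyl (a 2.3-fold lower number from compound 1 to compound 3 (0.35 log units; beyond the scatter)). The two chlorinated phenyl groups did not separate, so only compound 3 shows that the aryl group on this oxygen can move the number, and it holds the lowest of the three. No measurement here explains this change. Still open, from the compounds shown here alone, is whether the bromine or its ring place carries the step, as 2-chlorophenyl or 4-bromophenyl would tell, and how a pyridine ring or a longer chain would compare.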